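Replacing Bromo with Hydrogen: Expected Cytotoxicity of Compound 4

This account rests on a few compounds, and the source may have more. Where it says the series, first, only, none or still open, it means among the compounds named here.

Of the compounds shown here, three have been tested in an ADME assay on MT4 cells (Homo sapiens) for cytotoxicity, read by MTT assay, with a stated time of 96 h; on this read-out higher numbers stand for lower toxicity in this test and lower numbers for higher toxicity in this test. Compound 1 `S=C(Nc1ccc(Cl)c(Cl)c1)Nc1nc[nH]n1` gives 47000 nM, compound 2 `S=C(Nc1cccc(Br)c1)Nc1nc[nH]n1` gives 50000 nM, and compound 3 `Nc1ncnn1/C(S)=N/Cc1ccccc1` gives 7400 nM. Compound 2 thus holds the highest of the three numbers; its gap to compound 1 lies within the scatter, while its gap to compound 3 lies beyond it. Compound 4 `S=C(Nc1ccccc1)Nc1nc[nH]n1` differs from compound 2 by hydrogen in place of bromo on an aromatic carbon. For the measured compounds named here, no measured pair shows this change, so the step from compound 2 to compound 4 in this assay is expected to be small, in no particular direction, and not beyond the scatter. In this assay compound 4 is expected to give 60000 nM, within a range from 25000 nM to 150000 nM. This expected step amounts to a 1.2-fold higher number from compound 2 to compound 4 (0.08 log units; within the scatter).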

Compound 4, half-maximal cytotoxic concentration: > 100000 nM
Compound 4: only a limit was reported; the forecaster's own chance of this, stated with the estimate: 30%; at least 1.6-fold (0.22 log units) between middle value and limit.
By their numbers in this assay, from the lowest: compound 3; then compounds 1 and 2 (each within the scatter of the next). At a limit, above all of these: compound 4.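

In this assay compound 4 gives > 100000 nM, which is a limit and not a number. Hydrogen in place of bromo on this aromatic carbon, a change no earlier pair could show, gives an at least 2.0-fold higher number from compound 2 to compound 4 (0.30 log units; that floor lies within the scatter), so the bromo is not needed here for a high number in this test. That floor is all that can be said of the size of the step: the limit of > 100000 nM in this assay, at which 1 of the 4 values shown sits.

The compounds shown leave open how an amine or a carboxylic acid at this place on the aromatic ring would read. They also leave open how fluoro would compare with bromo and hydrogen here.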